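From Trifluoromethyl to Chloro on a Shared Core

A few compounds are considered here, and "the series" means these few. Any claim that something is new, unique, unknown or untested is made for them only; others in the source may bear on it.

Compound 1, `Cc1ccccc1-c1cncc(OC[C@@H]2CCCN2C)c1`: 1.1 nM
Compound 2, `CN1CCC[C@H]1COc1cncc(-c2ccc(C(F)(F)F)cc2)c1`: 0.15 nM

Both compounds were measured in an assay on membranes from brain for binding affinity to Neuronal acetylcholine receptor; alpha4/beta2 (Rattus norvegicus); on this read-out lower numbers stand for stronger inhibition and higher numbers for weaker inhibition. Among the measured compounds shown here, compound 2 stands lowest of the two numbers; compound 1 is its only neighbour, and the gap between them lies beyond the scatter, so compound 2 is the stronger binder of the pair.

Compound 3, `CN1CCC[C@H]1COc1cncc(-c2ccc(Cl)cc2)c1`, shares the core of compound 2 and differs from it in one place: chloro in place of trifluoromethyl on an aromatic carbon. For the measured compounds named here, no measured pair shows this exchange, so nothing in these data tells how large such a step is. With chloro entering where trifluoromethyl leaves, a small step is expected, at most a modest weakening and possibly none beyond the scatter. The expected step is a 2.0-fold higher number from compound 2 to compound 3 (0.30 log units; within the scatter). Compound 3 is estimated at 0.3 nM, with a range from 0.08 nM to 1.2 nM.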

Compound 3, inhibition constant: 0.082 nM
Estimate against measurement, compound 3: 3.7-fold (0.56 log units) above, within the range that was stated.
By their numbers in this assay, from the lowest: compounds 3 and 2 (each within the scatter of the next); then compound 1.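

In this assay, chloro in place of trifluoromethyl on the aromatic carbon para to a large group gives a 1.8-fold lower number from compound 2 to compound 3 (0.26 log units; within the scatter), so at this position one chlorine atom serves as well as the four heavy atoms of trifluoromethyl, as far as the scatter allows this to be told. By contrast, 4-chlorophenyl in place of 2-methylphenyl gives a 13-fold lower number from compound 1 to compound 3 (1.13 log units; beyond the scatter), a large step, which shows that the aromatic group on the shared core can matter far more than the exchange between compound 2 and compound 3 suggested. No measurement at hand bears on the reason for either step.

On these data alone, it remains open whether this position also accepts an amine, a carboxylic acid or a longer chain. As far as these compounds go, it is also open whether the large step follows from the group itself or from its place on the ring, a question that 4-methylphenyl on the same core would address.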